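Sulfonyl-linked chloropropylurea series: cytotoxicity notes

The source may hold more compounds than are shown below. What is called first, only, known or untested is meant among the compounds shown, and "the series" means these compounds.

Four compounds share a chloropropylurea on an aromatic ring that also carries a sulfonyl group. Compound 1 `O=C(NCCCCl)Nc1cccc(S(=O)(=O)Oc2ccc(O)cc2)c1` and compound 2 `O=C(NCCCCl)Nc1ccc(S(=O)(=O)Oc2ccc(O)cc2)cc1` have the same atoms joined differently; how their two cores differ is not broken down here. In a functional assay on M21 cells (Homo sapiens) for cytotoxicity, read by sulforhodamine B assay, with a stated time of 48 h (on this read-out lower numbers stand for stronger inhibition and higher numbers for weaker inhibition), compound 1 gives 49000 nM, and in the same this assay compound 2 gives 47000 nM. These two values lie within the scatter of each other, so no order between them is claimed.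

Compound 3 `Cc1ccccc1NS(=O)(=O)c1cccc(NC(=O)NCCCCl)c1` is derived from compound 1 by (2-methylphenyl)amino in place of 4-hydroxyphenoxy on a sulfonyl sulfur. In this assay compound 3 gives 60000 nM; the measured step is a 1.2-fold higher number from compound 1 to compound 3 (0.09 log units; within the scatter), which does not stand apart from the scatter. The same change, taken at the same place, would carry compound 2 to compound 4 `Cc1ccccc1NS(=O)(=O)c1ccc(NC(=O)NCCCCl)cc1`, an unmeasured compound: (2-methylphenyl)amino in place of 4-hydroxyphenoxy on a sulfonyl sulfur. The surroundings of the place are described in the same words for both pairs, so the change is taken as the same one.

Within the data shown here, the expected step is a 1.2-fold higher number from compound 2 to compound 4 (0.08 log units; within the scatter), and it rests on the earlier step because the one measured example gave a 1.2-fold higher number from compound 1 to compound 3 (0.09 log units; within the scatter) and nothing else in the set speaks for a larger move. For compound 4 the expected value in this assay is 56000 nM, estimated to lie between 30000 nM and 105000 nM. Among the measured compounds shown here, only one pair supports this, so the expectation is weak.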

Compound 4, half-maximal inhibitory concentration: > 200000 nM
Compound 4: a limit, no number; the forecaster's own chance of this, stated with the estimate: 15%; middle value at least 3.5-fold (0.55 log units) away from the limit.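

In this assay compound 4 gives > 200000 nM, which is a limit of the assay and not a number. The swap of 4-hydroxyphenoxy for (2-methylphenyl)amino on a sulfonyl sulfur gives an at least 4.2-fold higher number from compound 2 to compound 4 (0.62 log units; beyond the scatter), and it therefore does not carry unchanged from the core of compound 1 to the core of compound 2: the same change on two cores in this assay, a 1.2-fold higher number (0.09 log units; within the scatter) from compound 1 to compound 3 and an at least 4.2-fold higher number (0.62 log units; beyond the scatter) from compound 2 to compound 4, at least 3.4-fold (0.54 log units) apart, beyond the scatter of two such steps What this does not show is the true size of the step on the core of compound 2, or any reason for the difference between cores, and it rests on a single pair per core, with the limit standing as the only one of its kind in the set: the limit of > 200000 nM in this assay, at which 1 of the 4 values shown sits.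

The compounds shown leave open whether the dependence on the core holds for other groups on the sulfonyl sulfur, such as a plain phenylamino, a piperidine amine or a group carrying a carboxylic acid. They also leave open whether it persists when the chloropropyl chain on the urea is replaced by a longer chain, and which part of the exchanged group, the linking atom or the ring substituent, accounts for the result.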